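What replacing one end of compound 3 may do

The compounds below may be only part of what the source reports. "The series", "measured", "known", "first", "only" and "open" are said of these compounds alone.

In a functional assay on SW-620 cells (Homo sapiens) for inhibition, read by MTT assay, with a stated time of 72 h (a higher number here means a weaker inhibitor, a lower number a stronger inhibitor), compound 1 `COc1cc(NC(C)CCCNC(=O)NNC(=O)Nc2ccc(F)cc2)c2ncccc2c1` gives > 100000 nM, which is a limit and not a number. Compound 3 `COc1cc(NC(C)CCCNC(=O)NNC(=O)Nc2cccc(F)c2)c2ncccc2c1` gives 9500 nM and compound 2 `COc1cc(NC(C)CCCNC(=O)Nc2cc(C(F)(F)F)cc(C(F)(F)F)c2)c2ncccc2c1` gives 3900 nM, so compound 3 holds the higher of the two actual numbers and is the weaker inhibitor of that pair.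

Compound 4 `COc1cc(NC(C)CCCNC(=O)Nc2cccc(C(F)(F)F)c2)c2ncccc2c1` changes one end of compound 3: 3-(trifluoromethyl)phenyl in place of ((3-fluorophenyl)carbamoyl)amino on an amide-type nitrogen. In words, 3-(trifluoromethyl)phenyl stands in place of ((3-fluorophenyl)carbamoyl)amino on an amide-type nitrogen.

Among the measured compounds shown here, no measured step makes this change. The only one available, an at least 10-fold lower number from compound 1 to compound 3 (1.02 log units; beyond the scatter), is large and shows that a change in this part of the molecule can move the number far, so the range must stay wide. The closest guide is compound 2 at 3900 nM, which also carries a trifluoromethyl-bearing phenyl on that nitrogen. The step expected is a 1.9-fold lower number from compound 3 to compound 4 (0.28 log units; within the scatter), a modest one toward a lower number. For compound 4 the estimated value is 5000 nM, with an expected range from 1500 nM to 20000 nM.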

Compound 4, half-maximal inhibitory concentration: 22000 nM
Beside the measured number, compound 4's estimate is 4.4-fold (0.64 log units) below it; the whole stated range lies below it.
By their numbers in this assay, from the lowest: compound 2; then compound 3; then compound 4. At a limit, above all of these: compound 1.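

Replacing the ((3-fluorophenyl)carbamoyl)amino end with 3-(trifluoromethyl)phenyl on the amide-type nitrogen removes that whole end, and the number does not fall as compound 2 had suggested but rises: a 2.3-fold higher number from compound 3 to compound 4 (0.36 log units; beyond the scatter). The trifluoromethyl groups on the ring also matter, as hydrogen in place of one trifluoromethyl on an aromatic carbon gives a 5.6-fold higher number from compound 2 to compound 4 (0.75 log units; beyond the scatter). The remaining step, an at least 4.5-fold lower number from compound 1 to compound 4 (0.65 log units; beyond the scatter), starts from a limit and not a number, so its true size is unknown: the limit of > 100000 nM in this assay, at which 1 of the 4 values shown sits.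

The compounds shown do not tell what an amine or a carboxylic acid would do in place of trifluoromethyl on an aromatic carbon. Nor do they tell how a longer chain would change the number.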